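The source may hold more compounds than are shown below. What is called first, only, known or untested is meant among the compounds shown, and "the series" means these compounds.

In a functional assay on PC-3 cells (Homo sapiens) for antiproliferative activity, read by MTT assay, with a stated time of 48 h (on this read-out lower numbers stand for stronger inhibition and higher numbers for weaker inhibition), compound 2 `Brc1ccc(-c2nnc(-c3cn4ccccc4n3)o2)cc1` gives > 50000 nM, which is a limit of the assay and not a number. Compound 1 `COc1ccc(-c2nnc(-c3cn4ccccc4n3)o2)cc1` gives 13400 nM. For the measured compounds named here, the only measured step, an at least 3.7-fold higher number from compound 1 to compound 2 (0.57 log units; beyond the scatter), is bromo in place of methoxy on an aromatic carbon, a different change at a different place. Compound 3 `Cc1cccn2cc(-c3nnc(-c4ccc(Br)cc4)o3)nc12` carries methyl in place of hydrogen on an aromatic carbon, so no measured step sizes this change directly. In this assay the expected change is small, an estimated at least 1.2-fold lower number from compound 2 to compound 3 (0.09 log units; that floor lies within the scatter). Compound 3 is expected at 40000 nM, within an estimated range of 14000 nM to 50000 nM.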

Compound 3, half-maximal inhibitory concentration: 37800 nM
Compound 3: middle estimate off by 1.1-fold (0.02 log units), on the high side, within the range that was stated.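

In this assay, methyl in place of hydrogen on an aromatic carbon of the six-membered ring with 1 nitrogen gives an at least 1.3-fold lower number from compound 2 to compound 3 (0.12 log units; that floor lies within the scatter). The bromo compound with this methyl group therefore gives a measured number, which shows that this carbon can carry the group without the value reaching the assay limit. How large the step really is stays unknown, because compound 2 has only a limit and not a number: the limit of > 50000 nM in this assay, at which 1 of the 3 values shown sits.

On these data alone, it remains open whether an amine or a longer chain on this carbon would move the number further. As far as these compounds go, it is also open whether methyl would have a similar effect with the methoxy group of compound 1 in place of bromo.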